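Swapping a hydroxymethyl for an acetamide arm

A few compounds are considered here, and "the series" means these few. Any claim that something is new, unique, unknown or untested is made for them only; others in the source may bear on it.

Measured so far in this set:
- compound 1 `O=C(O)CC/C=C\CO[C@H]1C(OCc2ccc(-c3ccc(CO)cc3)cc2)CC[C@@H]1N1CCCCCC1`: 20 nM
- compound 2 `O=C(O)CC/C=C\CO[C@H]1[C@@H](OCc2ccc(-c3ccccc3)cc2)CC[C@@H]1N1CCCCC1`: 31.6 nM; 50.1 nM (2 entries)
- compound 3 `CS(=O)(=O)Nc1ccccc1-c1ccc(CO[C@H]2CC[C@H](N3CCCCCC3)[C@H]2OC/C=C\CCC(=O)O)cc1`: 63.1 nM

In a functional assay for antagonist activity at thromboxane A2 receptor (Rattus norvegicus) (on this read-out lower numbers stand for tighter binding and higher numbers for weaker binding), compound 1 gives 20 nM, the lowest of the two single numbers available. Its nearest neighbour is compound 3, which gives 63.1 nM, a gap that lies beyond the usual scatter. Compound 2 has no single number, only (the several entries of compound 2 in this assay, 31.6 nM; 50.1 nM (2 entries)), so it is left out of the ordering.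

Compound 4 `NC(=O)Cc1ccccc1-c1ccc(COC2CC[C@H](N3CCCCCC3)[C@H]2OC/C=C\CCC(=O)O)cc1` has not yet been measured. It differs from compound 1 in one place: a group of 10 heavy atoms (8 carbon, 1 nitrogen, 1 oxygen; one six-membered aromatic ring of carbon only) in place of a group of 8 heavy atoms (7 carbon, 1 oxygen; one six-membered aromatic ring of carbon only), on an aromatic carbon. The group that leaves carries a hydroxyl; the group that enters carries an amide and sits on the outer ring of the shared core. Going by the values given here, compound 3 is the only measured example with a polar substituent placed on that outer ring in this way, and in this assay compound 3 gives 63.1 nM.

Among the compounds with values here, no step between two measured compounds matches this change, so the expectation for compound 4 rests on compound 1 and compound 3 alone. A weakening of moderate size, beyond the scatter, is expected, a 2.5-fold higher number from compound 1 to compound 4 (0.40 log units; beyond the scatter). The estimated value for compound 4 in this assay is 50 nM, with a range from 15 nM to 160 nM.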

Compound 4, dissociation constant: 158 nM
Estimate against measurement, compound 4: 3.2-fold (0.50 log units) below; low and high end bracket the measured number.
By their numbers in this assay, from the lowest: compound 1; then compound 3; then compound 4.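

Going by these compounds alone, this is the first direct step at this place on the shared core, an aromatic carbon para to a large group, and it shows that the place is sensitive to what sits there: in this assay, exchanging 4-(hydroxymethyl)phenyl for the amide-bearing group gives a 7.9-fold higher number from compound 1 to compound 4 (0.90 log units; beyond the scatter), a change beyond the usual scatter. The group that leaves and the group that enters have the same hydrogen-bond donor and acceptor counts and no net charge, yet their numbers differ clearly, so those counts alone do not predict the outcome at this place. Nothing on hand explains the step, as the only supporting data concern repeat entries of compound 2, which plays no part in this change.

A single step cannot separate the contribution of the amide from that of the larger group with its additional heavy atoms. As far as these compounds go, it also remains open whether a carboxylic acid or an amine on the same arm, or a longer chain ending in a hydroxyl, would give a number close to that of compound 1 at 20 nM or one as high as that of compound 4 at 158 nM.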